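Compound 3 to compound 4: a furan-2-yl swap

The source may hold more compounds than are shown below. What is called first, only, known or untested is meant among the compounds shown, and "the series" means these compounds.

In a functional assay on HCT-116 cells (Homo sapiens) for antiproliferative activity, read by MTT assay (a lower number here means a stronger inhibitor, a higher number a weaker inhibitor), compound 3 `Cn1c(=O)c(=O)n(C2CCCC2)c2nc(N/N=C/c3ccc(O)c(F)c3)ncc21` gives 59300 nM and lies within the scatter of compound 1 `Cn1c(=O)c(=O)n(C2CCCC2)c2nc(N/N=C/c3ccc(O)cc3)ncc21` at 72500 nM on these numbers. Compound 2 `Cn1c(=O)c(=O)n(C2CCCC2)c2nc(N/N=C/c3ccc(F)c(Cl)c3)ncc21` gives a clearly lower 9020 nM in the same test. Compound 4 `Cn1c(=O)c(=O)n(C2CCCC2)c2nc(N/N=C/c3ccco3)ncc21` carries furan-2-yl in place of 3-fluoro-4-hydroxyphenyl on a carbon with a double bond to nitrogen. Adding fluoro barely mattered (a 1.2-fold lower number from compound 1 to compound 3 (0.09 log units; within the scatter)). Whole-group exchanges at this same place mattered more (an 8.0-fold lower number from compound 1 to compound 2 (0.91 log units; beyond the scatter); a 6.6-fold higher number from compound 2 to compound 3 (0.82 log units; beyond the scatter)). Among the measured compounds shown here, compound 2 is the only measured compound without a hydroxy group, and no furan-2-yl compound has been measured. A modest fall is therefore expected, an estimated 2.4-fold lower number from compound 3 to compound 4 (0.38 log units; beyond the scatter) in this assay terms. The estimate for compound 4 is 25000 nM (range 8000 nM to 70000 nM).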

Compound 4, half-maximal inhibitory concentration: 78700 nM
For compound 4 the middle estimate is 3.1-fold (0.50 log units) below the measured one, and the stated range ends below it.
By their numbers in this assay, from the lowest: compound 2; then compounds 3, 1 and 4 (each within the scatter of the next).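

In this assay the step of a 1.3-fold higher number from compound 3 to compound 4 (0.12 log units; within the scatter) and the step of a 1.1-fold higher number from compound 1 to compound 4 (0.04 log units; within the scatter) both stay within the scatter, so furan-2-yl, a five-membered aromatic ring, does no better here than the hydroxy-bearing phenyl groups. Compound 4 has no hydroxy group either, yet an 8.7-fold higher number from compound 2 to compound 4 (0.94 log units; beyond the scatter) shows that losing that group does not by itself bring the lower number seen for compound 2. No available evidence explains this result.

Going by these compounds, it remains open whether the chloro group, the fluoro group or both together matter in compound 2. An amine or a carboxylic acid at this place is also untested among the compounds shown.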